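The source may report more compounds than this note shows. Statements on the series, on what has been measured and on what is new or still open speak of the compounds shown alone.

Measured so far:
compound 1 `C/C(=N/Nc1nc(-c2ccc([N+](=O)[O-])cc2)cs1)c1cccnc1` gives "not active" (no number reported)
compound 2 `C/C(=N/Nc1nc(-c2ccc(F)cc2)cs1)c1cccnc1` gives 40%
compound 3 `C/C(=N/Nc1nc(-c2ccc(F)cc2)cs1)c1ccncc1` gives 40%

In an in vitro assay on BTI-TN-5B1-4 cells for inhibition of Amine oxidase [flavin-containing] A (Homo sapiens), read by Amplex Red, with a stated time of 15 min, tested at 100 uM (on this read-out lower numbers stand for less inhibition and higher numbers for more inhibition at the one concentration tested (going by the name of the read-out)), compound 2 gives 40%. Compound 3, which carries pyridin-4-yl in place of pyridin-3-yl on a carbon with a double bond to nitrogen, gives 40% in this assay, and the step of no change at the digits printed from compound 2 to compound 3 (within the scatter) lies within the scatter. For compound 1 only a verdict without a number was reported in this assay; compound 1 gives "not active" (no number reported). Going by the values given here, no step between compound 1 and compound 2 is given, so their two values simply stand side by side.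

Compound 4 `C/C(=N/Nc1nc(-c2ccc(F)cc2F)cs1)c1cccnc1` has not yet been measured. It differs from compound 2 in one place: fluoro in place of hydrogen on an aromatic carbon. Among the compounds with values here, no measured step touches this part of the shared core, so the only comparison at hand is the one from compound 2 to compound 3, which brought no change beyond the scatter. Compound 1 shows that a change on this ring can matter, but without a number its size cannot be weighed. On that basis the step is expected to be no change at the digits printed from compound 2 to compound 4 (within the scatter). The estimate for compound 4 in this assay is 40%, with a range from 20% to 60%.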

Compound 4, a percentage reported as inhibition, at one concentration (the size of the read-out at that concentration, not a potency): 40%
For compound 4 middle estimate and measured number coincide at the digits printed, and the stated range covers the measured number.
By their numbers in this assay, from the lowest: compounds 2, 3 and 4 (each within the scatter of the next).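

In this assay, the added fluoro, on an aromatic carbon ortho to a large group and meta to a fluoro group, gives no change at the digits printed from compound 2 to compound 4 (within the scatter). Going by these compounds alone, this is the first step with numbers at both ends on the six-membered aromatic ring of carbon only, as the earlier step, no change at the digits printed from compound 2 to compound 3 (within the scatter), concerned the pyridine end of the molecule; this position therefore takes one more fluorine atom with no shift beyond the scatter, while compound 1, which differs on the same ring, gives "not active" (no number reported), a verdict with no number to set against this step. Nothing measured here speaks to why the value stays level at this position.

The compounds shown leave open whether a group larger than fluoro at this same place, such as a methoxy group, an amine or a carboxylic acid, would keep the value level. They also leave open whether the added fluoro would give the same result on the core of compound 3, which carries pyridin-4-yl.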